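A few compounds are considered here, and "the series" means these few. Any claim that something is new, unique, unknown or untested is made for them only; others in the source may bear on it.

Measured so far in an ADME assay (Homo sapiens) for cytotoxicity; a lower number here means that less compound is tolerated, a higher number that more compound is tolerated:
- compound 1 `CC(=O)N1CCC(C(=O)N(CCCN2CCC(CNc3cc(C)ccn3)CC2)c2ccc(C)c(Cl)c2)CC1` gives 17900 nM.
- compound 2 `CC(=O)N1CCC(C(=O)N(CCCN2CCN(Cc3ccncc3)CC2)c2ccc(C)c(Cl)c2)CC1` gives only a limit, > 56700 nM.
- compound 3 `CC(=O)N1CCC(C(=O)N(CCCN2CCC(CNC(=O)c3ccsc3)CC2)c2ccc(C)c(Cl)c2)CC1` gives only a limit, > 51900 nM.

Compound 2 thus stands at the limit of this assay, with no number of its own; compound 3 also sits at a limit, so only compound 1 gives a number, and it lies lower than either limit.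

Compound 4 `CC(=O)N1CCC(C(=O)N(CCCN2CCN(c3ccccn3)CC2)c2ccc(C)c(Cl)c2)CC1` differs from compound 2 in one place: pyridin-2-yl in place of (pyridin-4-yl)methyl on an amine nitrogen in a ring. Going by the values given here, no measured step matches this change. Among the compounds with values here, the single measured step, an at least 2.8-fold higher number from compound 1 to compound 3 (0.46 log units; beyond the scatter), is a change on an amine nitrogen as well, and it moves from a number for compound 1 to the limit for compound 3 (the limit of > 51900 nM in this assay, at which 1 of the 3 values shown sits). That step bears on the present one only loosely: it shows that a compound bearing a pyridinyl group on an amine nitrogen, compound 1, gave a number, while the two compounds without such a group, compound 2 the limit of > 56700 nM in this assay, at which 1 of the 3 values shown sits, and compound 3, did not.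

For compound 4 a small downward step from the limit of compound 2 is therefore expected, an at least 1.8-fold lower number from compound 2 to compound 4 (0.27 log units; that floor lies within the scatter), though with a fair chance that this assay again reports only a limit. The estimate for compound 4 is 30000 nM, expected between 10000 nM and 60000 nM.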

Compound 4, half-maximal cytotoxic concentration: > 58300 nM
Compound 4 gave a limit, no number; the forecaster's own chance of this, stated with the estimate: 40%; middle value at least 1.9-fold (0.28 log units) from the limit.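

In this assay compound 4 gives only a limit, > 58300 nM. Compound 2 also gives only a limit, > 56700 nM, so no step can be read between compound 2 and compound 4. The compounds shown leave open whether pyridin-2-yl and (pyridin-4-yl)methyl on this ring amine nitrogen differ at all in this assay.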